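This account rests on a few compounds, and the source may have more. Where it says the series, first, only, none or still open, it means among the compounds named here.

Measured compounds:
compound 1, `COc1nc(C)c(Nc2nc(Cl)cn([C@H](COC(=O)c3ccccn3)C3CC3)c2=O)cc1C`, gives 67 nM in an assay on frontal cortex for displacement of a labelled ligand from corticotropin-releasing factor receptor 1 (Rattus norvegicus), with a stated time of 2 h; a lower number here means a stronger inhibitor, a higher number a weaker inhibitor;
compound 2, `COc1nc(C)c(Nc2nc(Cl)cn([C@H](COC(=O)Nc3ccccc3Cl)C3CC3)c2=O)cc1C`, gives 1.5 nM in this assay.

Among the compounds with values here, compound 2 holds the lower of the two numbers; the only measured step, a 45-fold lower number from compound 1 to compound 2 (1.65 log units; beyond the scatter), is large and sets it well apart from compound 1. Compound 3, `COc1nc(C)c(Nc2nc(Cl)cn([C@H](COC(=O)Nc3ccc(Cl)cc3)C3CC3)c2=O)cc1C`, differs from compound 2 by 4-chlorophenyl in place of 2-chlorophenyl on an amide-type nitrogen. Within the data shown here, no measured step speaks to this change: the one step recorded, a 45-fold lower number from compound 1 to compound 2 (1.65 log units; beyond the scatter), exchanges the whole group on the carbonyl carbon for another, whereas here one chlorophenyl simply replaces the other on the amide-type nitrogen. The data therefore give no ground for a shift in either direction, and the step expected is one that stays within the usual scatter, a 2.0-fold higher number from compound 2 to compound 3 (0.30 log units; within the scatter). For compound 3 the value expected in this assay is 3 nM, with a range from 0.8 nM to 15 nM.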

Compound 3, half-maximal inhibitory concentration: 1.6 nM
Compound 3: middle estimate off by 1.9-fold (0.27 log units), on the high side; the measured number falls inside the stated range.
By their numbers in this assay, from the lowest: compounds 2 and 3 (each within the scatter of the next); then compound 1.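

In this assay, 4-chlorophenyl in place of 2-chlorophenyl on the amide-type nitrogen gives a 1.1-fold higher number from compound 2 to compound 3 (0.03 log units; within the scatter), so the two chlorophenyl groups cannot be told apart at this position. The large step seen earlier is therefore not tied to 2-chlorophenyl alone: (4-chlorophenyl)amino in place of pyridin-2-yl on the carbonyl carbon also gives a large step, a 42-fold lower number from compound 1 to compound 3 (1.62 log units; beyond the scatter). No measurement offered here accounts for this result.

The compounds shown leave open whether the chlorine matters at all, since neither a plain phenyl nor a cyclohexyl on the amide-type nitrogen appears among them. They also leave open whether the amide-type nitrogen itself contributes to the step, as a pyridin-2-yl carried on that nitrogen is not among them either.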